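Moving the chlorine on the ester-bearing ring of compound 3

The compounds below may be only part of what the source reports. "The series", "measured", "known", "first", "only" and "open" are said of these compounds alone.

Three esters of a shared core have been measured in an ADME assay on cells (T-cell, Mus musculus, strain BALB/c) for cytotoxicity, read by MTT assay, with a stated time of 48 h; a lower number here means that less compound is tolerated, a higher number that more compound is tolerated. Compound 1 `COC(=O)c1cc(Cl)ccc1OC(=O)COc1cc(O)c2c(=O)cc(-c3ccccc3)oc2c1` reaches only the limit of the assay, > 436000 nM. Compound 2 `COC(=O)c1c(Br)cc(Br)cc1OC(=O)COc1cc(O)c2c(=O)cc(-c3ccccc3)oc2c1` gives 398000 nM in this assay. Compound 3 `COC(=O)c1ccc(C)cc1OC(=O)COc1cc(O)c2c(=O)cc(-c3ccccc3)oc2c1` gives 250000 nM in this assay, a value within the scatter of that of compound 2. For the measured compounds named here, the only single-point step among them runs an at least 1.7-fold lower number from compound 1 to compound 3 (0.24 log units; that floor lies within the scatter); it rests on the limit of > 436000 nM in this assay, at which 1 of the 3 values shown sits, and so gives a floor for the size of the step, not its true size.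

Compound 4 `COC(=O)c1cccc(Cl)c1OC(=O)COc1cc(O)c2c(=O)cc(-c3ccccc3)oc2c1` differs from compound 3 in one place: a group of 11 heavy atoms (8 carbon, 2 oxygen, 1 chlorine; one six-membered aromatic ring of carbon only) in place of a group of 11 heavy atoms (9 carbon, 2 oxygen; one six-membered aromatic ring of carbon only), on an oxygen next to a carbonyl group. The measured step from compound 1 to compound 3 concerns the same place and the exchange of a chlorine-bearing ester ring for a methyl-bearing one; the change to compound 4 returns a chlorine-bearing ring, though with the chlorine in another arrangement. A modest step towards a higher number in this assay is therefore expected, quite possibly within the scatter. For compound 4 the expected step is a 1.4-fold higher number from compound 3 to compound 4 (0.15 log units; within the scatter). Compound 4 is thus estimated at 350000 nM, with a range from 180000 nM to 600000 nM.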

Compound 4, half-maximal cytotoxic concentration: 366000 nM
Compound 4: the middle estimate sits 1.0-fold (0.02 log units) below what was measured; measured number inside the range.
By their numbers in this assay, from the lowest: compounds 3, 4 and 2 (each within the scatter of the next). At a limit, above all of these: compound 1.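

The exchange on the oxygen next to a carbonyl group gives a 1.5-fold higher number from compound 3 to compound 4 (0.17 log units; within the scatter) in this assay, so the methyl-bearing group and 2-chloro-6-(methoxycarbonyl)phenyl are not told apart at this place. For the compounds shown here, compound 4 also allows the first comparison of two chlorine-bearing groups at this place, with 2-chloro-6-(methoxycarbonyl)phenyl in place of the 4-chloro-2-(methoxycarbonyl)phenyl of compound 1, and the result is an at least 1.1-fold lower number from compound 1 to compound 4 (0.07 log units; that floor lies within the scatter). The number for compound 1 is a limit, so this step shows only that its floor does not leave the scatter, and its true size remains unknown: the limit of > 436000 nM in this assay, at which 1 of the 4 values shown sits.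

The compounds shown therefore do not settle whether rearranging the two groups on this ring changes the number in this assay beyond the scatter. Also open, on these data alone, is whether a carboxylic acid in place of the methoxycarbonyl group, or an amine on the same ring, would give a number that stands clear of those of compound 2, compound 3 and compound 4.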